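Ethynyl for Vinyl on a Saturated Ring Carbon

The source may report more compounds than this note shows. Statements on the series, on what has been measured and on what is new or still open speak of the compounds shown alone.

Compound 1 `CC[C@@]1(O)[C@H](O)[C@@H](CO)O[C@H]1n1cnc2c(N)ncnc21`: in an ADME assay on A549 cells (Homo sapiens) for cytotoxicity, read by luminescence, CellTiter-Glo and ATP content (a higher number here means that more compound is tolerated, a lower number that less compound is tolerated), compound 1 gives > 100000 nM, a limit of the assay.
Compound 2 `C=C[C@@]1(O)[C@H](O)[C@@H](CO)O[C@H]1n1cnc2c(N)ncnc21`: in this assay compound 2 gives > 59000 nM, also a limit of the assay.

Compound 2 therefore stands only at a limit, and no number is known for it. The step that the two limits leave unreadable from compound 1 to compound 2 cannot be read. Compound 1 sits at the limit of > 100000 nM in this assay, at which 1 of the 2 values shown sits. Compound 2 sits at the limit of > 59000 nM in this assay, at which 1 of the 2 values shown sits. Compound 3 `C#C[C@@]1(O)[C@H](O)[C@@H](CO)O[C@H]1n1cnc2c(N)ncnc21` differs from compound 2 by ethynyl in place of vinyl on a saturated ring carbon. No readable measured step bears on this change, so nothing beyond the scatter is expected in this assay. Compound 3 is expected at 100000 nM, within 30000 nM to 300000 nM, probably again as a limit. The step that the limit leaves unreadable from compound 2 to compound 3 is expected to stay within the scatter.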

Compound 3, half-maximal cytotoxic concentration: 40000 nM
Compound 3: the middle estimate sits 2.5-fold (0.40 log units) above what was measured, within the range that was stated.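

In this assay, among these compounds, compound 3 is the first of the three compounds to give a number rather than a limit. Ethynyl on this saturated ring carbon shows an at least 2.5-fold lower number from compound 1 to compound 3 (0.39 log units; beyond the scatter), and an at least 1.4-fold lower number from compound 2 to compound 3 (0.16 log units; that floor lies within the scatter). Ethynyl is thus set apart from ethyl at this position but not yet from vinyl, and the step from ethyl stays a floor because compound 1 stands at a limit: the limit of > 100000 nM in this assay, at which 1 of the 3 values shown sits.

From the compounds shown here alone, the true size of both steps stays open. So does the effect of a longer chain such as propyl, or of an amine, at this position.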